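Second methyl on the amide-bearing ring of compound 1

This account rests on a few compounds, and the source may have more. Where it says the series, first, only, none or still open, it means among the compounds named here.

Compound 1 `CCNC(=O)c1ccc(-c2cc3nnn(C4CCN(c5ncc(CC)cn5)CC4)c3cn2)cc1C` is measured in a functional assay on HEK293 cells for agonist activity at Glucose-dependent insulinotropic receptor (Homo sapiens), read by HTRF and cAMP accumulation, with a stated time of 30 min (a higher number here means that more compound is needed for the effect, a lower number that less compound is needed), and gives 18 nM. It stands level with compound 2 `CCNC(=O)c1ccc(-c2cc3nnn(C4CCN(c5ncc(CC)cn5)CC4)c3cn2)cc1Cl`, which gives 18 nM, together the lowest of the three numbers; the step of no change at the digits printed from compound 1 to compound 2 (within the scatter) lies within the scatter. The furthest neighbour is compound 3 `CCNC(=O)c1ccc(-c2cc3nnn(C4CCN(c5ncc(CC)cn5)CC4)c3cn2)cc1C(F)(F)F`, which gives 39 nM, the step of a 2.2-fold higher number from compound 1 to compound 3 (0.34 log units; beyond the scatter) being modest, as is a 2.2-fold higher number from compound 2 to compound 3 (0.34 log units; beyond the scatter).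

Compound 4 `CCNC(=O)c1c(C)cc(-c2cc3nnn(C4CCN(c5ncc(CC)cn5)CC4)c3cn2)cc1C` differs from compound 1 by methyl in place of hydrogen on an aromatic carbon. Among the measured compounds shown here, no measured step touches this place: the three steps exchange the substituent that compound 1 already carries, with chloro leaving the number unchanged and trifluoromethyl raising it modestly. For the measured compounds named here, they therefore show only that the ring carrying the ethylcarbamoyl group accepts small changes without a large movement in this assay. For compound 4 a small step is expected, a 1.4-fold higher number from compound 1 to compound 4 (0.14 log units; within the scatter), likely within or barely beyond the scatter. Compound 4 is therefore estimated at 25 nM, with a range from 10 nM to 60 nM.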

Compound 4, half-maximal effective concentration: 27 nM
Compound 4: middle estimate off by 1.1-fold (0.03 log units), on the low side, within the range that was stated.
By their numbers in this assay, from the lowest: compounds 1, 2, 4 and 3 (each within the scatter of the next, the first and the last beyond it).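

In this assay, methyl in place of hydrogen on this aromatic carbon, ortho to an ethylcarbamoyl group, gives a 1.5-fold higher number from compound 1 to compound 4 (0.18 log units; within the scatter). This tests a place that the exchanges in compounds 2 and 3 did not touch. The methyl group is tolerated here, and compound 4, with its additional methyl group, cannot be told apart from compound 1 in this assay. The data shown offer nothing that would explain this result.

On these data alone, whether an amine, a methoxy group or a longer chain on this carbon would also leave the number close to that of compound 1 remains open. So does whether chloro or trifluoromethyl would behave here as they do in compounds 2 and 3, where they replace the methyl group of compound 1.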